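From compound 2 to compound 3: a cytotoxicity expectation

The source may hold more compounds than are shown below. What is called first, only, known or untested is meant among the compounds shown, and "the series" means these compounds.

Compound 1 `CCCCNc1nc(N)nc2ccn(Cc3cccc(C)n3)c12`: > 24000 nM
Compound 2 `CCC(O)CNc1nc(N)nc2ccn(Cc3ccccn3)c12`: > 24000 nM

Both values come from an ADME assay on HEK293 cells (Homo sapiens) for cytotoxicity, read by ATP content, with a stated time of 6 h; a higher number here means that more compound is tolerated, a lower number that less compound is tolerated. Compound 1 gives only a limit there, > 24000 nM. Compound 2 likewise gives only a limit, > 24000 nM. Compound 2 therefore stands at the limit of > 24000 nM in this assay, at which 2 of the 2 values shown sit, with no exact number of its own. Compound 3 `Cc1cnc(CNc2nc(N)nc3ccn(Cc4ccccn4)c23)s1` is not yet measured and differs from compound 2 by 5-methyl-1,3-thiazol-2-yl in place of 1-hydroxypropyl on a saturated chain carbon bound to a nitrogen on an aromatic ring. Among the measured compounds shown here, no measured pair shows what such a change does in this assay, so the expected step is none beyond the scatter. Compound 3 is expected to remain at the limit, which means a step that the limit leaves unreadable from compound 2 to compound 3. The estimate for compound 3 is 30000 nM, between 12000 nM and 80000 nM.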

Compound 3, half-maximal cytotoxic concentration: > 24000 nM
Compound 3: only a limit was reported; the forecaster's own chance of this, stated with the estimate: 80%; the middle value is on the limit's open side.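

Compound 2 and compound 3 both give only a limit in this assay, so no step can be read between them: the limit of > 24000 nM in this assay, at which 3 of the 3 values shown sit.

The compounds shown leave open what concentration of each is half-maximally cytotoxic, and whether 5-methyl-1,3-thiazol-2-yl in place of 1-hydroxypropyl changes it.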